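Swapping a Butyl Chain for a Cyclopentyloxy Group

A few compounds are considered here, and "the series" means these few. Any claim that something is new, unique, unknown or untested is made for them only; others in the source may bear on it.

Compound 1 `CCCCc1ccc(Nc2nc(C)cs2)cc1` carries a butyl chain on an aromatic carbon, and in an ADME assay on microsomes from liver (Rattus norvegicus) for metabolic stability, with a stated time of 30 min, tested at 1 uM (on this read-out lower numbers stand for a less stable compound and higher numbers for a more stable compound), compound 1 gives 1%. Compound 2 `Cc1csc(Nc2ccc(C(C)C)cc2)n1` bears an isopropyl group at that carbon instead, and in this assay compound 2 gives 0%. Compound 3 `CCC(O)Cc1ccc(Nc2nc(C)cs2)cc1` carries a 2-hydroxybutyl group there, and in this assay compound 3 gives 1%. Compound 1 thus sits level with compound 3, and all three numbers fall within the scatter of one another: a number 1 percentage points lower from compound 1 to compound 2 (within the scatter), no change at the digits printed from compound 1 to compound 3 (within the scatter) and a number 1 percentage points higher from compound 2 to compound 3 (within the scatter) are each too small to count as a change. Compound 4 `Cc1csc(Nc2ccc(OC3CCCC3)cc2)n1` is the one still to be measured; it differs from compound 1 in a single place: cyclopentyloxy in place of butyl on an aromatic carbon. The two steps that exchange the group on this same aromatic carbon, a number 1 percentage points lower from compound 1 to compound 2 (within the scatter) and a number 1 percentage points higher from compound 2 to compound 3 (within the scatter), bear most directly on the change, and both left the read-out flat at the bottom of the scale. Among the compounds with values here, nothing among the measured compounds suggests that yet another replacement at this carbon would lift the number beyond the scatter, so a number 1 percentage points higher from compound 1 to compound 4 (within the scatter) is the step expected here. The estimate for compound 4 is therefore 2%, with a range from 0% to 15%.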

Compound 4, percent of the compound remaining: 10%
Estimate against measurement, compound 4: 8 percentage points below, and the stated range covers the measured number.
By their numbers in this assay, from the lowest: compounds 2, 1, 3 and 4 (each within the scatter of the next).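

In this assay the steps of a number 9 percentage points higher from compound 1 to compound 4 (within the scatter) and a number 9 percentage points higher from compound 3 to compound 4 (within the scatter) and a number 10 percentage points higher from compound 2 to compound 4 (within the scatter) are all printed as within the scatter, so a fourth group on this aromatic carbon still gives no readable change. The earlier compounds shown here tested only open chains here, whereas cyclopentyloxy has 6 heavy atoms against the 4 of butyl and brings one five-membered non-aromatic ring and 1 hydrogen-bond acceptor, so the result extends the flat picture at this position to a group of a different shape and make-up. Nothing at hand accounts for these numbers or says what happens to the compounds in the microsomes.

The compounds shown do not separate the ring from the oxygen, so a plain cyclopentyl group or a short methoxy group at the same carbon would be needed to tell the two apart. From the compounds shown here alone, it also remains open whether a quite different group here, such as an amine or a carboxylic acid, would give a step beyond the scatter, or whether changes elsewhere on the shared core would matter more.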